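N-Methylation of a Ring Amine on a Potent Sulfone

The source may report more compounds than this note shows. Statements on the series, on what has been measured and on what is new or still open speak of the compounds shown alone.

The compounds here share a sulfone-bearing bicyclic core fitted with a saturated ring amine. Compound 1 `O=S(=O)(c1ccc(F)cc1)c1cn(C2CCNC2)c2ncccc12` carries a fluorophenyl sulfone and a pyrrolidine whose nitrogen bears a hydrogen. In an assay on HeLa cells for displacement of a labelled ligand from 5-hydroxytryptamine receptor 6 (Homo sapiens) (a lower number here means a stronger inhibitor, a higher number a weaker inhibitor), compound 1 gives 8.5 nM. Compound 2 `CN1CCC(n2cc(S(=O)(=O)c3ccc(F)cc3)c3cccnc32)C1` differs from it only as described by methyl in place of hydrogen on an amine nitrogen in a ring, and in this assay compound 2 gives 5 nM. The step of a 1.7-fold lower number from compound 1 to compound 2 (0.23 log units; within the scatter) shows that adding the methyl changed little here.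

Compound 3 `O=S(=O)(C1=C(Cl)NC2SC=CN12)c1cn(C2CCCNC2)c2ncccc12` replaces the fluorophenyl with a chlorinated bicyclic heteroaryl sulfone and uses a piperidine instead of a pyrrolidine; the difference between the two cores is not broken down here. In this assay compound 3 gives 0.7 nM, the lowest of the three numbers and beyond the scatter from both compounds 1 and 2.

Compound 4 `CN1CCCC(n2cc(S(=O)(=O)C3=C(Cl)NC4SC=CN34)c3cccnc32)C1` has not yet been measured. It differs from compound 3 by methyl in place of hydrogen on an amine nitrogen in a ring. This is the same kind of change seen between compound 1 and compound 2, though the place differs: there the amine nitrogen sits in a five-membered non-aromatic ring with 1 nitrogen, here in a six-membered non-aromatic ring with 1 nitrogen. Because the earlier step of a 1.7-fold lower number from compound 1 to compound 2 (0.23 log units; within the scatter) was small, the step from compound 3 to compound 4 is expected to be similarly modest, about a 1.4-fold lower number from compound 3 to compound 4 (0.15 log units; within the scatter). Compound 4 is therefore estimated to give 0.5 nM in this assay, with a likely range from 0.2 nM to 1.5 nM.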

Compound 4, inhibition constant: 2 nM
For compound 4 the middle estimate is 4.0-fold (0.60 log units) below the measured one; measured number above the stated range.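

In this assay, putting methyl in place of hydrogen on the amine nitrogen of the piperidine gives a 2.9-fold higher number from compound 3 to compound 4 (0.46 log units; beyond the scatter), while the same swap on the pyrrolidine gave a 1.7-fold lower number from compound 1 to compound 2 (0.23 log units; within the scatter). The size of this change therefore does not carry unchanged from one core to the other in this series, and the step seen on one core was not a safe guide to the step on the other: the same change on two cores in this assay, a 1.7-fold lower number (0.23 log units; within the scatter) from compound 1 to compound 2 and a 2.9-fold higher number (0.46 log units; beyond the scatter) from compound 3 to compound 4, 4.9-fold (0.69 log units) apart, beyond the scatter of two such steps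

This does not show why the two steps differ, nor does it give a general rule, since it rests on just two pairs of compounds and their cores differ both in the ring amine and in the group on the sulfone, so either difference, or the two together, could lie behind the gap.

The compounds shown leave open how the same methyl step would behave with the fluorophenyl sulfone on a piperidine or with the chlorinated sulfone group on a pyrrolidine, pairings that would help separate those two differences. They also leave open what an ethyl group, a longer chain or an acetyl group on that same ring nitrogen would do in this assay.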